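Bromo in Place of Fluoro: Expected Cytotoxicity of Compound 4

The compounds below may be only part of what the source reports. "The series", "measured", "known", "first", "only" and "open" are said of these compounds alone.

Compound 1, `C=CCOc1ccc(F)cc1C(=O)c1cccnc1`: in a functional assay on PC-3 cells (Homo sapiens) for cytotoxicity, read by sulforhodamine B assay, with a stated time of 48 h (a lower number here means a stronger inhibitor, a higher number a weaker inhibitor), compound 1 gives only a limit, > 100000 nM.
Compound 2, `O=C(c1cccnc1)c1cc(F)ccc1O`: in this assay compound 2 gives 11800 nM.
Compound 3, `C=CCOc1c(Cl)cccc1C(=O)c1cccnc1`: in this assay compound 3 gives only a limit, > 100000 nM.

Compound 2 is the only one of the three with a number in this assay; the other two sit at a limit, as the limit of > 100000 nM in this assay, at which 2 of the 3 values shown sit, shows. Among the measured compounds shown here, the one step that can be measured runs from compound 1 to compound 2, an at least 8.4-fold lower number from compound 1 to compound 2 (0.92 log units; beyond the scatter), hydrogen in place of allyl on the oxygen.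

Compound 4, `O=C(c1cccnc1)c1cc(Br)ccc1O`, is not yet measured. It differs from compound 2 by bromo in place of fluoro on an aromatic carbon, a bromo in place of a fluoro on an aromatic carbon, para to the hydroxy group. No measured step touches that halogen; the only step shown concerns the allyl group, so it gives no direct guide to the size or direction of this change. Compound 4 is therefore expected to lie close to compound 2, with a step of a 1.2-fold lower number from compound 2 to compound 4 (0.07 log units; within the scatter) that stays within the scatter. The estimate for compound 4 in this assay is 10000 nM, from 3000 nM to 35000 nM.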

Compound 4, half-maximal inhibitory concentration: 60200 nM
The estimate for compound 4 lay 6.0-fold (0.78 log units) below the measured number, and the stated range ends below it.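

Among the compounds shown here, the halogen on this carbon, which no earlier step had touched, turns out not to be a neutral place for change: in this assay the exchange gives a 5.1-fold higher number from compound 2 to compound 4 (0.71 log units; beyond the scatter). With the hydroxy group kept in place, bromo in place of fluoro on this aromatic carbon, para to a hydroxy group, therefore moves the result in the weaker direction, by more than repeated measurements would scatter. Compound 4 still gives a number and not a limit, so this step can be read with a size as well as a direction, which the step from the allyl compound could not offer: the limit of > 100000 nM in this assay, at which 2 of the 4 values shown sit.

This is a single pair, and no other step involving these halogens can be read, so it sets no trend and does not tell why the number rises. As far as these compounds go, whether hydrogen, a methyl group, a methoxy group, a nitrile or an amine on this carbon would stay near fluoro, near bromo or beyond either remains open, as does the effect of a longer chain or a carboxylic acid there.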